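The compounds below may be only part of what the source reports. "The series", "measured", "known", "first", "only" and "open" are said of these compounds alone.

Three compounds sharing one core and one attachment point have been examined in a functional assay on CHO cells for agonist activity at Alpha-2C adrenergic receptor (Homo sapiens); a higher number here means that more compound is needed for the effect, a lower number that less compound is needed. Compound 1 `CC(Oc1ccccc1C=O)C1=NCCN1` gives 100 nM in this assay. Compound 2 `CC(C)Oc1ccccc1OC(C)C1=NCCN1` gives 100 nM, and compound 3 `CCc1ccccc1OC(C)C1=NCCN1` gives 100 nM. Between them the steps are flat: no change at the digits printed from compound 1 to compound 2 (within the scatter), no change at the digits printed from compound 1 to compound 3 (within the scatter) and no change at the digits printed from compound 2 to compound 3 (within the scatter). Compound 3 therefore stands level with compounds 1 and 2 at the digits shown, neither set apart from compound 1 nor from compound 2, so that nothing in this series yet separates one substituent on that aromatic carbon from another.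

Compound 4 `COc1ccccc1OC(C)C1=NCCN1` is the next member. It differs from compound 3 as follows: methoxy in place of ethyl on an aromatic carbon. For the measured compounds named here, the steps that bear on this exchange are the three already recorded, since each of them also swaps the group on the same aromatic carbon, and each of them stayed within the scatter, the exchange of isopropoxy for ethyl in no change at the digits printed from compound 2 to compound 3 (within the scatter) being the closest in kind. On that basis compound 4 is expected to show no step beyond the scatter, the estimated step being no change at the digits printed from compound 3 to compound 4 (within the scatter). The value expected for compound 4 in this assay is 100 nM, with a range from 40 nM to 250 nM.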

Compound 4, half-maximal effective concentration: 9770 nM
For compound 4 the middle estimate is 98-fold (1.99 log units) below the measured one; the measured number lies above the stated range.
By their numbers in this assay, from the lowest: compounds 1, 2 and 3 (each within the scatter of the next); then compound 4.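

In this assay this aromatic carbon is no longer indifferent to its substituent, for the record now holds a 98-fold higher number from compound 3 to compound 4 (1.99 log units; beyond the scatter) and a 98-fold higher number from compound 2 to compound 4 (1.99 log units; beyond the scatter) as well as a 98-fold higher number from compound 1 to compound 4 (1.99 log units; beyond the scatter) at a place where formyl, isopropoxy and ethyl had stood level. The step from compound 2 is the most pointed, since it exchanges only isopropyl for methyl on the oxygen, so an oxygen on the aromatic ring does not by itself set compound 4 apart: compound 2 carries one too and stays with compounds 1 and 3. The step from compound 3 keeps the heavy-atom count printed for the group and exchanges one carbon for one oxygen, which shows that the earlier flatness was no general tolerance at this position and that a change of this small size can carry a large step.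

No measurement at hand accounts for the jump. Still open, on these data alone, is where the change sets in along the chain on that oxygen, that is, whether ethoxy or a free hydroxyl on the same carbon would stand with compound 2 or with compound 4.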